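Dimethylamino in place of amino on a thiocarbonyl carbon

The compounds below may be only part of what the source reports. "The series", "measured", "known", "first", "only" and "open" are said of these compounds alone.

- compound 1 `NC(=S)N/N=C/c1cc2cccnc2s1`: limit, > 100000 nM
- compound 2 `NC(=S)N/N=C/c1nc2ccccc2s1`: limit, > 100000 nM
- compound 3 `CN(C)C(=S)N/N=C/c1cnc2ccccc2n1`: 90 nM

All values come from a functional assay on HL-60 cells (Homo sapiens) for antiproliferative activity, read by sulforhodamine B assay, with a stated time of 72 h; a lower number here means a stronger inhibitor, a higher number a weaker inhibitor. Compound 2 gives no number and stands at the limit of > 100000 nM in this assay, at which 2 of the 3 values shown sit. The next step leads to compound 4 `CN(C)C(=S)N/N=C/c1nc2ccccc2s1`, with dimethylamino in place of amino on a thiocarbonyl carbon. Among the measured compounds shown here, no measured pair tests this change. For the measured compounds named here, compound 3 carries dimethylamino on a different core and gives 90 nM, the only number so far. A large step towards stronger inhibition in this assay is therefore expected, though its size is uncertain. The expected change is an at least 330-fold lower number from compound 2 to compound 4 (2.52 log units; beyond the scatter). Compound 4 is estimated at 300 nM, with an expected range of 40 nM to 3000 nM.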

Compound 4, half-maximal inhibitory concentration: 3680 nM
Beside the measured number, compound 4's estimate is 12-fold (1.09 log units) below it, and the stated range ends below it.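

In this assay, the thiocarbonyl carbon is a position where the change counts on this core: dimethylamino in place of amino gives an at least 27-fold lower number from compound 2 to compound 4 (1.43 log units; beyond the scatter). Among the compounds shown here, this is the first measured pair for the change, which previously had only compound 3, on a different core, to suggest it. Compound 2 gives > 100000 nM, a limit and not a number, so the step has a bound rather than a size.

As far as these compounds go, whether the same change lowers the number on the core of compound 1 stays open. Also open, from the compounds shown here alone, is how diethylamino or morpholine would compare with dimethylamino at this place.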